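Adding ethyl to the nitrogen of compound 1

A few compounds are considered here, and "the series" means these few. Any claim that something is new, unique, unknown or untested is made for them only; others in the source may bear on it.

In a functional assay on the whole organism with Mus musculus as the target (a lower number here means that less compound is needed, a higher number that more compound is needed for the effect), compound 1 (`Cc1c(C)c2c(c(C)c1N)CC(C)(C)O2`) gives 7.8 mg/kg. Compound 3 (`Cc1c(C)c2c(c(C)c1N)C(C(C)C)C(C)(C)O2`) gives 14 mg/kg, within the scatter of that value, while compound 2 (`CC(C)=Cc1c(C)c(N)c(C)c2c1OC(C)(C)C2`) gives 21.9 mg/kg, beyond it.

The next compound to be tested is compound 4 (`CCNc1c(C)c(C)c2c(c1C)CC(C)(C)O2`), which has ethyl in place of hydrogen on a nitrogen on an aromatic ring. Within the data shown here, no measured step changes that nitrogen, so the available evidence is only indirect. Two measured steps put a larger group elsewhere on the shared core. The first is a 2.8-fold higher number from compound 1 to compound 2 (0.45 log units; beyond the scatter), and the second is a 1.8-fold higher number from compound 1 to compound 3 (0.25 log units; within the scatter). Both point upward, but only the first clears the scatter. A similar small upward step in this assay is therefore expected, and it may not clear the scatter either. The expected change is a 1.7-fold higher number from compound 1 to compound 4 (0.22 log units; within the scatter). For compound 4 the estimated value is 13 mg/kg. The estimated range for compound 4 runs from 5 mg/kg to 35 mg/kg.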

Compound 4, dose for 50% inhibition: 38.9 mg/kg
Compound 4: the middle estimate sits 3.0-fold (0.48 log units) below what was measured; measured number outside the range, above it.
By their numbers in this assay, from the lowest: compounds 1, 3, 2 and 4 (each within the scatter of the next, the first and the last beyond it).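

Among these compounds, compound 4 is the only compound here changed on the nitrogen itself, and in this assay ethyl in place of hydrogen there gives a 5.0-fold higher number from compound 1 to compound 4 (0.70 log units; beyond the scatter) as its step. This nitrogen is therefore not indifferent to substitution: ethyl alone is enough to carry the number beyond the scatter, meaning that more compound is needed for the effect. Nothing available bears on the reason for this rise.

Among the compounds shown here, with ethyl as the only group on this nitrogen, it remains open whether methyl or a longer chain such as propyl would give a similar step, or whether an acetyl group, which would turn the amine into an amide, would behave differently. From the compounds shown here alone, it is also open whether ethyl on the nitrogen would raise the number to the same extent in compound 2 or compound 3.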